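Bromo Added to a Methoxybenzamide: Expected Cytotoxicity

The source may report more compounds than this note shows. Statements on the series, on what has been measured and on what is new or still open speak of the compounds shown alone.

Measured compounds and their values:
compound 1, `COc1ccc(Br)cc1C(=O)Nc1ccccc1`: > 100000 nM
compound 2, `COc1c(Br)cccc1C(=O)Nc1cccc(Cl)c1`: > 100000 nM
compound 3, `COc1ccccc1C(=O)Nc1cccc(Cl)c1`: > 100000 nM

In an ADME assay on HEK293 cells (Homo sapiens) for cytotoxicity, read by reporter gene assay and resazurin assay, with a stated time of 48 h (on this read-out higher numbers stand for lower toxicity in this test and lower numbers for higher toxicity in this test), compound 1 gives > 100000 nM, which is a limit of the assay rather than a number. Compound 2 gives > 100000 nM, again a limit. Compound 3 gives > 100000 nM, also a limit. For the measured compounds named here, compound 3 thus stands where every measured value sits, at the limit of > 100000 nM in this assay, at which 3 of the 3 values shown sit, and no compound can be placed above or below another. Going by the values given here, the single measured step, a step that the two limits leave unreadable from compound 2 to compound 3, cannot be read, since both of its ends are limits.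

Compound 4, `COc1ccc(Br)cc1C(=O)Nc1cccc(Cl)c1`, is not yet measured. It differs from compound 3 in one place: bromo in place of hydrogen on an aromatic carbon. The same bromo group is present in compound 1, which also gives only a limit. Among the compounds with values here, no measured step therefore bears on this change in a readable way; the only step on record is unreadable, so no direction can be drawn from it.

Given that compound 1 and compound 3 both sit at the limit, compound 4 is expected to do the same, and the step of a number no higher from compound 3 to compound 4 (the limit leaves the size open) is expected to be none beyond the scatter. Compound 4 is estimated at 100000 nM, within 50000 nM to 200000 nM.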

Compound 4, half-maximal cytotoxic concentration: > 100000 nM
Compound 4 ended at the assay's limit (the forecaster's own chance of this, stated with the estimate: 85%); the middle value sits exactly at the limit.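

Compound 4 adds no readable step: its comparisons with compound 1 and compound 3 cannot be read, because both ends of each are limits of the assay, not numbers: the limit of > 100000 nM in this assay, at which 4 of the 4 values shown sit.

In this assay the compounds shown leave open whether bromo or chloro on the shared core changes toxicity at all, as none can be placed above or below another.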